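The source may report more compounds than this note shows. Statements on the series, on what has been measured and on what is new or still open speak of the compounds shown alone.

For the measured compounds named here, in a physicochemical assay for solubility, at pH 7.4 (a lower number here means a less soluble compound, a higher number a more soluble compound), compound 1 `CN1CCN(c2ccccc2C(=O)/C=C/c2ccc(/C=C/C(=O)NO)cc2)CC1` gives 210000 nM and stands highest of the two numbers so far, while compound 2 `CN1CCN(c2cccc(C(=O)/C=C/c3cccc(/C=C/C(=O)NO)c3)c2)CC1` gives 46000 nM and lies lower by more than the usual scatter. Compound 3 `O=C(/C=C/c1ccc(/C=C/C(=O)c2ccccc2)cc1)NO` has not yet been measured. Its structure differs from that of compound 1 in one place, hydrogen in place of 4-methylpiperazin-1-yl on an aromatic carbon with hydrogen in place of 4-methylpiperazin-1-yl on an aromatic carbon. Going by the values given here, both measured compounds carry 4-methylpiperazin-1-yl, so no measured pair shows this change directly and the expectation remains a judgement. A large move toward a lower number, well beyond the scatter, is expected, and the estimated step is a 35-fold lower number from compound 1 to compound 3 (1.54 log units; beyond the scatter) for this replacement. Compound 3 is estimated at 6000 nM with an expected range from 1000 nM to 30000 nM on this scale.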

Compound 3, solubility: 3000 nM
Compound 3: the middle estimate sits 2.0-fold (0.30 log units) above what was measured; the range from low to high includes it.
By their numbers in this assay, from the lowest: compound 3; then compound 2; then compound 1.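

In this assay, for the compounds shown here, this pair gives the first direct reading of the change, with a 70-fold lower number from compound 1 to compound 3 (1.85 log units; beyond the scatter) when hydrogen replaces 4-methylpiperazin-1-yl on the aromatic carbon ortho to a large group. The two earlier compounds both carried 4-methylpiperazin-1-yl, so they could not show what this place contributes, whereas this pair shows that the number depends heavily on what occupies it. No measurement shown here accounts for the size of this step.

One pair cannot tell whether a smaller amine such as dimethylamino, a morpholine ring or a carboxylic acid at this place would give a step of similar size. It also leaves open whether the same replacement would give a comparable step on the core of compound 2.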